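Replacing the nitrophenyl group: what to expect of compound 4

The compounds below may be only part of what the source reports. "The series", "measured", "known", "first", "only" and "open" are said of these compounds alone.

Measured compounds:
compound 1 `COc1ccc2[nH]c3c(c2c1)CCNC31CCN(Cc2ccc([N+](=O)[O-])cc2F)CC1` — 5900 nM
compound 2 `COc1ccc2[nH]c3c(c2c1)CCNC31CCN(Cc2c(F)ccc(Cl)c2F)CC1` — 1500 nM
compound 3 `COc1ccc2[nH]c3c(c2c1)CCNC31CCN(Cc2ccc(Br)c(F)c2)CC1` — 1800 nM

In an assay on FRT cells for positive allosteric modulation of Cystic fibrosis transmembrane conductance regulator variant N1303K (Homo sapiens), in the presence of a further agent that is not named here (a higher number here means that more compound is needed for the effect, a lower number that less compound is needed), compound 1 gives 5900 nM, the highest of the three numbers. Compound 4 `COc1ccc2[nH]c3c(c2c1)CCNC31CCN(Cc2cc(F)ccc2F)CC1` differs from compound 1 in one place: 2,5-difluorophenyl in place of 2-fluoro-4-nitrophenyl on a saturated chain carbon bound to an amine nitrogen in a ring. Going by the values given here, two measured steps bear on this change, since each also replaces the nitrophenyl group with a halogenated phenyl group: a 3.9-fold lower number from compound 1 to compound 2 (0.59 log units; beyond the scatter) and a 3.3-fold lower number from compound 1 to compound 3 (0.52 log units; beyond the scatter). The two halogenated analogues themselves differ by only a 1.2-fold higher number from compound 2 to compound 3 (0.08 log units; within the scatter). Compound 4 carries a smaller halogenated group, so a step in the same direction, of modest size, is expected: a 2.4-fold lower number from compound 1 to compound 4 (0.37 log units; beyond the scatter). Compound 4 is therefore estimated at 2500 nM, with a range from 1000 nM to 6000 nM.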

Compound 4, half-maximal effective concentration: 11100 nM
For compound 4 the middle estimate is 4.4-fold (0.65 log units) below the measured one; measured number above the stated range.
By their numbers in this assay, from the lowest: compounds 2 and 3 (each within the scatter of the next); then compounds 1 and 4 (each within the scatter of the next).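

In this assay, 2,5-difluorophenyl in place of 2-fluoro-4-nitrophenyl gives a 1.9-fold higher number from compound 1 to compound 4 (0.27 log units; within the scatter) and so shows that removing the nitro group does not by itself lower the number. At this position the identity of the halogens matters: the groups carrying chlorine or bromine lie lower, with a 6.2-fold higher number from compound 3 to compound 4 (0.79 log units; beyond the scatter) and a 7.4-fold higher number from compound 2 to compound 4 (0.87 log units; beyond the scatter) on moving to the group carrying only fluorine. Nothing available here explains this difference. Still open, as far as these compounds go, is whether chlorine or bromine, or their placement on the ring, sets the number. A 2,5-dichlorophenyl or 2,5-dibromophenyl group on the same carbon would separate the two.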